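Pyrrolidinyl to Piperidinyl Swap on Two Different Cores

A few compounds are considered here, and "the series" means these few. Any claim that something is new, unique, unknown or untested is made for them only; others in the source may bear on it.

Compound 1, `CCOCc1cc(CN2CCCC2)c(O)c2ncccc12`: 8510 nM in a functional assay on MES-SA cells (Homo sapiens) for inhibition, with a stated time of 72 h; on this read-out higher numbers stand for weaker inhibition and lower numbers for stronger inhibition
Compound 2, `CCOCc1cc(CN2CCCCC2)c(O)c2ncccc12`: 8710 nM
Compound 3, `Oc1c(C(c2cccnc2)N2CCCC2)ccc2cccnc12`: 40700 nM

Compound 1 and compound 2 share the same core and differ in one place: piperidin-1-yl in place of pyrrolidin-1-yl on a saturated chain carbon bound to an aromatic carbon. This change made a step of a 1.0-fold higher number from compound 1 to compound 2 (0.01 log units; within the scatter), so the two compounds cannot be told apart on this read-out. Compound 3 is built on a different core; how the core of compound 1 and the core of compound 3 differ is not broken down here. Compound 3 gives the highest of the three numbers, and its gap to each of the other two lies beyond the scatter, so among these three it is the weakest inhibitor.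

Compound 4, `Oc1c(C(c2cccnc2)N2CCCCC2)ccc2cccnc12`, has not yet been measured. It differs from compound 3 by piperidin-1-yl in place of pyrrolidin-1-yl on a saturated chain carbon bound to two aromatic carbons. Going by the values given here, this is the same kind of change as the one from compound 1 to compound 2, though the place is not identical: in the first pair the saturated chain carbon is bound to an aromatic carbon, while in compound 3 and compound 4 it is bound to two aromatic carbons. Among the compounds with values here, the only guide is the earlier pair, where the step was a 1.0-fold higher number from compound 1 to compound 2 (0.01 log units; within the scatter) and stayed within the scatter. On that basis the step from compound 3 to compound 4 is expected to be small, about a 1.0-fold lower number from compound 3 to compound 4 (0.01 log units; within the scatter) in this assay. Compound 4 is therefore estimated at 40000 nM, with a likely range from 18000 nM to 90000 nM.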

Compound 4, half-maximal inhibitory concentration: 13500 nM
Beside the measured number, compound 4's estimate is 3.0-fold (0.47 log units) above it, outside the stated range (below it).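

On the core of compound 3, piperidin-1-yl in place of pyrrolidin-1-yl gave a 3.0-fold lower number from compound 3 to compound 4 (0.48 log units; beyond the scatter) in this assay, which means stronger inhibition for the compound with the six-membered ring. Set side by side, the two steps do not match, so this swap did not carry over unchanged from the core of compound 1 to the core of compound 3: the same change on two cores in this assay, a 1.0-fold higher number (0.01 log units; within the scatter) from compound 1 to compound 2 and a 3.0-fold lower number (0.48 log units; beyond the scatter) from compound 3 to compound 4, 3.1-fold (0.49 log units) apart, beyond the scatter of two such steps

This shows that, in these two pairs, the result of the swap depends on its surroundings, but it does not show which difference between the cores matters, whether that is the saturated chain carbon being bound to two aromatic carbons rather than to one or some other part of the structure, and two pairs give no rule for any further core.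

The compounds shown leave open how other amines, such as morpholin-4-yl or an open-chain diethylamino group, would behave at this place on either core. Going by these compounds, it also remains open whether a third core carrying pyrrolidin-1-yl and piperidin-1-yl would follow the flat step of the first pair, the clearer step of the second, or neither.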